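Urea aryl variation on the diethylaminoethyl-amino thienopyrimidine series

The compounds below may be only part of what the source reports. "The series", "measured", "known", "first", "only" and "open" are said of these compounds alone.

Measured so far in a functional assay on HT-29 cells (Homo sapiens) for cytotoxicity, read by MTT assay, with a stated time of 72 h; a higher number here means a weaker inhibitor, a lower number a stronger inhibitor:
- compound 1, `CCN(CC)CCNc1nc(-c2ccc(NC(=O)Nc3ccc(Cl)cc3)cc2)nc2c(Cl)c(Cl)sc12`: 430 nM
- compound 2, `CCN(CC)CCNc1nc(-c2ccc(NC(=O)Nc3ccccc3Cl)cc2)nc2c(Cl)c(Cl)sc12`: 550 nM
- compound 3, `CCN(CC)CCNc1nc(-c2ccc(NC(=O)Nc3ccc(Cl)cc3Cl)cc2)nc2c(Cl)c(Cl)sc12`: 1140 nM

Compound 3 carries the highest number of the three in this assay; its nearest neighbour is compound 2 and the furthest is compound 1, both gaps lying beyond the scatter. Compound 4, `CCN(CC)CCNc1nc(-c2ccc(NC(=O)Nc3ccc(C)cc3)cc2)nc2c(Cl)c(Cl)sc12`, differs from compound 3 by 4-methylphenyl in place of 2,4-dichlorophenyl on an amide-type nitrogen. Within the data shown here, two measured steps bear on this: a 2.7-fold higher number from compound 1 to compound 3 (0.42 log units; beyond the scatter) and a 2.1-fold higher number from compound 2 to compound 3 (0.32 log units; beyond the scatter), both modest and both beyond the scatter. Each added a chloro on an aromatic carbon of the urea aryl group and raised the number; compound 4 sheds both chlorines, so the step back is expected to undo those increases. As far as these compounds go, the methyl that enters in compound 4 has no measured comparison in this set, so its own contribution is unknown. The step from compound 3 to compound 4 in this assay is therefore expected to be a 2.5-fold lower number from compound 3 to compound 4 (0.40 log units; beyond the scatter), landing compound 4 close to where compound 1 stands. Compound 4 is estimated at 450 nM, with a range of 200 nM to 1100 nM.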

Compound 4, half-maximal inhibitory concentration: 950 nM
Compound 4: middle estimate off by 2.1-fold (0.32 log units), on the low side, and the stated range covers the measured number.
By their numbers in this assay, from the lowest: compounds 1, 2, 4 and 3 (each within the scatter of the next, the first and the last beyond it).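

In this assay, methyl in place of chloro on an aromatic carbon gives a 2.2-fold higher number from compound 1 to compound 4 (0.34 log units; beyond the scatter) and so separates two aryl groups that each carry a single group, showing that the number at this amide-type nitrogen does not simply follow the count of chlorines on the aryl ring: compound 4 has none, yet it does not sit with compound 1. Going from 2,4-dichlorophenyl to 4-methylphenyl gives a 1.2-fold lower number from compound 3 to compound 4 (0.08 log units; within the scatter) and going from 2-chlorophenyl to 4-methylphenyl gives a 1.7-fold higher number from compound 2 to compound 4 (0.24 log units; within the scatter), so compound 4 cannot be told apart from compound 3 or compound 2 in this assay, and only compound 1 stands clear of compound 3 and compound 4. Nothing at hand explains why chloro and methyl part here.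

As far as these compounds go, how an unsubstituted phenyl, a fluorophenyl or a methoxyphenyl would stand on the same nitrogen remains open, and without the unsubstituted phenyl neither chloro nor methyl can be set against hydrogen at this place. Also open, from the compounds shown here alone, is whether the same order of aryl groups would hold with a morpholine or a longer chain in place of the diethylaminoethyl side chain on the shared core.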